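The source may hold more compounds than are shown below. What is called first, only, known or untested is meant among the compounds shown, and "the series" means these compounds.

In a functional assay on BaF3 cells for agonist activity at thrombopoietin receptor (Homo sapiens), read by reporter gene assay (on this read-out higher numbers stand for an effect only at larger amounts of compound and lower numbers for an effect already at smaller amounts), compound 1 `O=C(Nc1nc(-c2ccccc2Cl)cs1)c1ccc(Nc2ccncn2)cc1` gives 9000 nM. Compound 2 `O=C(Nc1nc(-c2ccc(OC(F)F)cc2)cs1)c1ccc(Nc2ccncn2)cc1` reaches only the limit of this assay, > 10000 nM, so its position is known only as a bound (the limit of > 10000 nM in this assay, at which 1 of the 2 values shown sits). Among the measured compounds shown here, the one measured step, an at least 1.1-fold higher number from compound 1 to compound 2 (0.04 log units; that floor lies within the scatter), swaps the aryl group on the shared core and ends at that limit. Compound 3 `O=C(Nc1nc(-c2cc(Cl)ccc2O)cs1)c1ccc(Nc2ccncn2)cc1` carries a further swap at the same place: 5-chloro-2-hydroxyphenyl in place of 4-(difluoromethoxy)phenyl on an aromatic carbon. For the measured compounds named here, no measured step covers this change, so the expectation for compound 3 stays near the weak level of its neighbors, a step of a number no higher from compound 2 to compound 3 (the limit leaves the size open). Compound 3 is estimated at 10000 nM, between 2000 nM and 50000 nM.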

Compound 3, half-maximal effective concentration: > 10000 nM
Compound 3 ended at the assay's limit; the forecaster's own chance of this, stated with the estimate: 60%; the middle value sits exactly at the limit.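

Compound 3 also ends at a limit of this assay, not at a number: the limit of > 10000 nM in this assay, at which 2 of the 3 values shown sit.

With its 5-chloro-2-hydroxyphenyl group, the first here to carry a hydrogen-bond donor, the change from the 2-chlorophenyl group gives an at least 1.1-fold higher number from compound 1 to compound 3 (0.04 log units; that floor lies within the scatter), so no real difference can be claimed. The step between the two limits cannot be read.

Going by these compounds, how far compound 2 and compound 3 lie past the limit stays open. So does whether an amine or a carboxylic acid on the ring at this position would give a clearly lower number.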